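This account rests on a few compounds, and the source may have more. Where it says the series, first, only, none or still open, it means among the compounds named here.

Measured in a functional assay on PC-3 cells (Homo sapiens) for inhibition, read by sulforhodamine B assay; on this read-out lower numbers stand for stronger inhibition of growth and higher numbers for weaker inhibition of growth:
Compound 1 `COc1cccc(CN2CCC=C(CCC(=O)NO)C2=O)c1`: > 10000 nM
Compound 2 `O=C(CCC1=CCCN(Cc2ccc(F)cc2)C1=O)NO`: "not determined" (no result reported)

Compound 2 has no number in this assay, so it cannot be placed on the scale. Compound 1 gives > 10000 nM, which is a limit of the assay and not a number. Within the data shown here, the only reference point near compound 2 is therefore the reading of compound 1: the limit of > 10000 nM in this assay, at which 1 of the 2 values shown sits.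

Compound 3 `O=C(CCC1=CCCN(Cc2ccc(NC(=O)c3ccccc3)cc2)C1=O)NO` differs from compound 2 by carrying benzamido in place of fluoro on an aromatic carbon, para to a large group: benzamido in place of fluoro on an aromatic carbon. Among the measured compounds shown here, no measured pair shows what such a change does. A moderate step toward stronger inhibition of growth, to lower numbers, is expected, though the reading may well stay at the limit of the assay. For compound 3 the expected value is 6000 nM, with an estimated range of 1500 nM to 25000 nM.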

Compound 3, concentration for 50% growth inhibition: > 10000 nM
Compound 3: no number, only a limit; the forecaster's own chance of this, stated with the estimate: 40%; middle value at least 1.6-fold (0.22 log units) away from the limit.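

In this assay compound 3 gives > 10000 nM, a limit of the assay and not a number. Among these compounds, compound 2 has no number, so no step between compound 2 and compound 3 can be read. The compounds shown leave open what benzamido in place of fluoro does to growth inhibition.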